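Adding a (4-formylphenyl)sulfonyl group to compound 1

A few compounds are considered here, and "the series" means these few. Any claim that something is new, unique, unknown or untested is made for them only; others in the source may bear on it.

Compound 1 `COc1ccc(-c2cc(=O)c3c(OC)cc(OC)cc3[nH]2)cc1` is the parent of this small set. In a functional assay on SUP-B15 cells (Homo sapiens) for antiproliferative activity, with a stated time of 72 h (on this read-out higher numbers stand for an effect only at larger amounts of compound and lower numbers for an effect already at smaller amounts), compound 1 gives only a limit, > 62000 nM. Compound 3 `COc1ccc(-c2[nH]c3cc(OC)cc(OC)c3c(=O)c2I)cc1` carries an iodo in place of hydrogen on an aromatic carbon; in this assay compound 3 also gives only a limit, > 86200 nM. The step that the two limits leave unreadable from compound 1 to compound 3 therefore cannot be read, as the limit of > 62000 nM in this assay, at which 1 of the 3 values shown sits, and the limit of > 86200 nM in this assay, at which 1 of the 3 values shown sits, show. Among the measured compounds shown here, compound 2 `COc1ccc(-c2c(Cl)c(=O)c3c(OC)cc(OC)cc3n2S(=O)(=O)c2ccc(OC)cc2)cc1` differs from compound 1 in two places, so no single step connects them; in this assay compound 2 gives 17900 nM, the one number among the three measured values.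

The change from compound 1 to compound 4 `COc1ccc(-c2cc(=O)c3c(OC)cc(OC)cc3n2S(=O)(=O)c2ccc(C=O)cc2)cc1` is (4-formylphenyl)sulfonyl in place of hydrogen on an aromatic nitrogen. For the measured compounds named here, no measured step matches this change, and the only sulfonyl-bearing comparator, compound 2, carries an additional chloro substituent, so its value can guide the estimate only loosely. On that basis compound 4 is expected to land near compound 2, estimated at 25000 nM with a range from 8000 nM to 80000 nM. The expected step of an at least 2.4-fold lower number from compound 1 to compound 4 (0.39 log units; beyond the scatter) starts from a limit and is thus itself only a bound; a measurement reporting another limit remains a real possibility.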

Compound 4, half-maximal effective concentration: > 34400 nM
Compound 4 gave a limit, no number (the forecaster's own chance of this, stated with the estimate: 35%); at least 1.3-fold (0.13 log units) between middle value and limit.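

In this assay compound 4 gives only a limit, > 34400 nM. Compound 1 is also only a limit, > 62000 nM, so no step can be read between compound 1 and compound 4. Still open, as far as these compounds go, is whether (4-formylphenyl)sulfonyl in place of hydrogen on the aromatic nitrogen shifts the antiproliferative read-out at all.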